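The compounds below may be only part of what the source reports. "The series", "measured", "known", "first", "only" and "open" are said of these compounds alone.

Measured so far:
compound 1 `Cn1c(-c2cccc([N+](=O)[O-])c2)cnc1NC(=O)c1ccc(F)cc1` gives > 50000 nM in a toxicity assay on THP-1 cells (Homo sapiens) for inhibition; on this read-out higher numbers stand for lower toxicity in this test and lower numbers for higher toxicity in this test
compound 2 `COc1ccc(-c2cnc(NC(=O)C3CCOCC3)n2C)cc1` gives > 100000 nM in this assay

Both numbers are limits of this assay, not measured values. Compound 1 sits at the limit (the limit of > 50000 nM in this assay, at which 1 of the 2 values shown sits). Compound 2 sits at the limit (the limit of > 100000 nM in this assay, at which 1 of the 2 values shown sits). On the numbers shown, compound 2 therefore stands only at a limit, with no real value to compare.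

Compound 3 `COc1ccc(-c2cnc(NC(C)=O)n2C)cc1` differs from compound 2 by methyl in place of oxan-4-yl on a carbonyl carbon. Among the measured compounds shown here, no step between measured compounds is available here. The step of a number no higher from compound 2 to compound 3 (the limit leaves the size open) is expected to be none beyond the scatter. Compound 3 is estimated at 100000 nM, with a range from 30000 nM to 300000 nM, and most likely the assay again reports only a limit.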

Compound 3, half-maximal cytotoxic concentration: > 100000 nM
Compound 3 was reported as a limit; the forecaster's own chance of this, stated with the estimate: 80%; the middle value lies on the limit itself.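

In this assay compound 3 gives > 100000 nM, which is a limit. Among the compounds shown here, compound 2 also stands at a limit, so no step between compound 2 and compound 3 can be read. Where the real toxicity value of any of the compounds shown lies stays open.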